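Removing one propanoyl ester from a polycyclic ketone core

A few compounds are considered here, and "the series" means these few. Any claim that something is new, unique, unknown or untested is made for them only; others in the source may bear on it.

Measured so far:
compound 1 `CCC(=O)Oc1ccc(C(=O)C2=C3OC(C)(C)[C@@H](CC=C(C)C)C[C@@]34C[C@@H](CC=C(C)C)C(C)(C)[C@H]3CCC(C)(C)O[C@]34OC2=O)cc1OC(=O)CC` with 9520 nM
compound 2 `CCCCCC(=O)Oc1ccc(C(=O)C2=C3OC(C)(C)[C@@H](CC=C(C)C)C[C@@]34C[C@@H](CC=C(C)C)C(C)(C)[C@H]3CCC(C)(C)O[C@]34OC2=O)cc1OC(=O)CCCCC` with 19900 nM

In a functional assay on HEL cells (Homo sapiens) for antiproliferative activity, read by MTT assay, with a stated time of 72 h (a higher number here means a weaker inhibitor, a lower number a stronger inhibitor), compound 1 gives 9520 nM, the lowest of the two numbers; compound 2 gives 19900 nM, a number beyond the scatter above it. Compound 1 carries two propanoyl esters on its aromatic ring, compound 2 two hexanoyl esters on the same core, and no other comparison is available.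

Compound 3 `CCC(=O)Oc1cc(C(=O)C2=C3OC(C)(C)[C@@H](CC=C(C)C)C[C@@]34C[C@@H](CC=C(C)C)C(C)(C)[C@H]3CCC(C)(C)O[C@]34OC2=O)ccc1O` keeps the core of compound 1 but differs in one place: hydrogen in place of propanoyl on an oxygen on an aromatic ring. Among the measured compounds shown here, this step from a doubly esterified compound to one with a free hydroxy group has no measured counterpart, so its size is uncertain. For the measured compounds named here, since the only change seen so far, a longer ester chain, went with the weaker number of compound 2 at 19900 nM, a shorter group is expected to keep or slightly lower the number, with the step of a 1.4-fold lower number from compound 1 to compound 3 (0.13 log units; within the scatter) expected to stay near the scatter. Compound 3 is therefore estimated at 7000 nM, between 2500 nM and 20000 nM.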

Compound 3, half-maximal inhibitory concentration: 9710 nM
Compound 3: the middle estimate sits 1.4-fold (0.14 log units) below what was measured; measured number inside the range.
By their numbers in this assay, from the lowest: compounds 1 and 3 (each within the scatter of the next); then compound 2.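

In this assay, putting hydrogen in place of propanoyl on an oxygen on an aromatic ring gives a 1.0-fold higher number from compound 1 to compound 3 (0.01 log units; within the scatter) and so leaves the two numbers indistinguishable. The earlier compounds shown here could not show this, as both carry an ester on each of the two oxygens; here, one propanoyl ester can be exchanged for a free hydroxy group with no change beyond the scatter. Nothing at hand explains this result.

Still open, going by these compounds, is whether the remaining propanoyl ester can also be replaced by hydrogen, leaving two free hydroxy groups on the ring. Also open is how a smaller acetyl ester, a methyl ether or an amine would read at this oxygen, since hydrogen is the only replacement shown here.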